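Aryl Swap on a Weakly Active Oxadiazole Scaffold

The source may hold more compounds than are shown below. What is called first, only, known or untested is meant among the compounds shown, and "the series" means these compounds.

Compound 1 `Fc1ccc2c(c1)CCC(c1nnc(-c3ccccc3Cl)o1)O2` has the highest of the two numbers in a functional assay (on this read-out higher numbers stand for weaker inhibition and lower numbers for stronger inhibition), where compound 1 gives 88000 nM. Compound 2 `Fc1ccc2c(c1)CCC(c1nnc(C3CCc4cc(F)ccc4O3)o1)O2` sits essentially level with it, giving 87000 nM in this assay, a gap that lies within the scatter. Compound 3 `Nc1ccc(-c2nnc(C3CCc4cc(F)ccc4O3)o2)cc1` carries 4-aminophenyl in place of 2-chlorophenyl on an aromatic carbon. Within the data shown here, no measured step of this kind is available, so the expectation rests only on the weak activity shared by compound 1 and compound 2. The step of a 1.3-fold lower number from compound 1 to compound 3 (0.10 log units; within the scatter) is expected to be small, none beyond the scatter. Compound 3 is estimated at 70000 nM, within a range of 20000 nM to 200000 nM.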

Compound 3, half-maximal inhibitory concentration: 89100 nM
Beside the measured number, compound 3's estimate is 1.3-fold (0.10 log units) below it; the range from low to high includes it.
By their numbers in this assay, from the lowest: compounds 2, 1 and 3 (each within the scatter of the next).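

In this assay, among these compounds, placing 4-aminophenyl instead of 2-chlorophenyl on this aromatic carbon gives a 1.0-fold higher number from compound 1 to compound 3 (0.01 log units; within the scatter), the first one-place comparison here. The entering group carries a hydrogen-bond donor and acceptor and the leaving group has none, yet the two cannot be told apart on this read-out. Nothing measured explains why they read alike.

As far as these compounds go, it remains open whether a carboxylic acid or a longer chain on this carbon would give a number beyond the scatter from compound 1.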